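The compounds below may be only part of what the source reports. "The series", "measured", "known", "first", "only" and "open" are said of these compounds alone.

Measured compounds:
- compound 1, `Cc1cc(N2CC[C@@H](C)[C@@H](N(C)c3ncnc4[nH]ccc34)C2)n2nc(SCc3ccc(F)cc3)nc2n1`: 26000 nM
- compound 2, `CCCCCc1c(C)nc2nc(SCc3ccc(Cl)cc3)nn2c1N1CC[C@@H](C)[C@@H](N(C)c2ncnc3[nH]ccc23)C1`: > 100000 nM
- compound 3, `CCc1cc(N2CC[C@@H](C)[C@@H](N(C)c3ncnc4[nH]ccc34)C2)n2ncnc2n1`: > 100000 nM

For the measured compounds named here, compound 1 is the only compound among the three with a number in a functional assay on HGC-27 cells (Homo sapiens) for inhibition, read by MTT assay, with a stated time of 72 h (on this read-out higher numbers stand for weaker inhibition and lower numbers for stronger inhibition), where compound 1 gives 26000 nM. Compound 2 reaches only a limit of this assay, > 100000 nM. Compound 3 likewise reaches only a limit of this assay, > 100000 nM. Two of the three values thus sit at the limit of > 100000 nM in this assay, at which 2 of the 3 values shown sit, so compound 1 is the one firm point from which to start.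

Compound 4, `Cc1cc(N2CC[C@@H](C)[C@@H](N(C)c3ncnc4[nH]ccc34)C2)n2nc(SCc3ccc(C(F)(F)F)cc3)nc2n1`, differs from compound 1 in one place: trifluoromethyl in place of fluoro on an aromatic carbon. Going by the values given here, no measured pair in this set carries the same change, so there is no step to lean on. The expected step from compound 1 to compound 4 is a 1.2-fold higher number from compound 1 to compound 4 (0.06 log units; within the scatter), which stays within the usual scatter. Compound 4 is therefore expected to give about 30000 nM in this assay, with a range from 8000 nM to 100000 nM.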

Compound 4, half-maximal inhibitory concentration: 9540 nM
Compound 4: middle estimate off by 3.1-fold (0.50 log units), on the high side, and the stated range covers the measured number.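

In this assay, putting trifluoromethyl in place of fluoro on the aromatic carbon para to a large group gives a 2.7-fold lower number from compound 1 to compound 4 (0.44 log units; beyond the scatter), so this position responds to the change by a modest step beyond the scatter. For the compounds shown here, this is the first single-place step that can be read here, and it runs toward stronger inhibition, with the larger group tolerated at this place. Compound 2 and compound 3 remain at a limit of the assay, and neither differs from compound 1 or compound 4 in one place only: the limit of > 100000 nM in this assay, at which 2 of the 4 values shown sit.

The compounds shown leave open whether a nitrile, a methoxy group or a carboxylic acid on that aromatic carbon would carry the number further in the same direction or turn it back. They also leave open how much of the inhibition rests on the (4-(trifluoromethyl)benzyl)sulfanyl group as a whole, as against a shorter or longer link to the aromatic ring.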